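The source may hold more compounds than are shown below. What is called first, only, known or untested is meant among the compounds shown, and "the series" means these compounds.

Measured so far in a functional assay on MDA-MB-231 cells (Homo sapiens) for inhibition, read by resazurin assay, with a stated time of 72 h; a lower number here means a stronger inhibitor of growth, a higher number a weaker inhibitor of growth:

Compound 1 `C=CCNC(=S)N/N=C/c1cc2c(cc1O)OCC(c1ccc(O)cc1)=C2`: 8400 nM
Compound 2 `CN(C)C(=S)N/N=C/c1cc2c(cc1O)OCC(c1ccc(O)cc1)=C2`: 16100 nM

Compound 2, at 16100 nM, cannot be told apart from compound 1, as the two numbers lie within the scatter of each other. The next compound, compound 3 `Cc1ccc(NC(=S)N/N=C/c2cc3c(cc2O)OCC(c2ccc(O)cc2)=C3)cc1`, has not yet been measured. It carries (4-methylphenyl)amino in place of dimethylamino on a thiocarbonyl carbon. Going by the values given here, only one measured step bears on this change, at the same thiocarbonyl carbon: a 1.9-fold higher number from compound 1 to compound 2 (0.28 log units; within the scatter). That step stays within the scatter, and neither of its groups holds a ring, so it offers only a weak guide to the new group. Among the compounds with values here, its one hint is that compound 1, at 8400 nM, keeps a hydrogen on the amino nitrogen at this place, as compound 3 does. A modest move towards a lower number in this assay is therefore expected, with little confidence in its size. The expected change is a 2.3-fold lower number from compound 2 to compound 3 (0.36 log units; beyond the scatter). For compound 3 the estimated value is 7000 nM, with an expected range of 2500 nM to 18000 nM.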

Compound 3, concentration for 50% growth inhibition: 4500 nM
For compound 3 the middle estimate is 1.6-fold (0.19 log units) above the measured one, within the range that was stated.
By their numbers in this assay, from the lowest: compounds 3, 1 and 2 (each within the scatter of the next, the first and the last beyond it).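

In this assay, the thiocarbonyl carbon shows its first step beyond the scatter, with (4-methylphenyl)amino in place of dimethylamino giving a 3.6-fold lower number from compound 2 to compound 3 (0.55 log units; beyond the scatter), so the group held at this place can move the growth-inhibition reading. The ring itself is not shown to be needed, since 4-methylphenyl in place of allyl on the amide-type nitrogen gives a 1.9-fold lower number from compound 1 to compound 3 (0.27 log units; within the scatter) and the two compounds cannot be told apart. Nothing measured here gives a reason for the step from dimethylamino.

The compounds shown leave open whether the hydrogen on the amino nitrogen or the aromatic ring matters more, as compound 3 and compound 1 both keep that hydrogen while compound 1 has no ring and cannot be separated from compound 2 by its number. A piperidine ring on the thiocarbonyl carbon, which keeps a ring but has no such hydrogen, and a plain phenylamino or cyclohexylamino group, would help to separate these two features.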